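Dimethylamino for hydroxy on the pyridyl arm

The source may report more compounds than this note shows. Statements on the series, on what has been measured and on what is new or still open speak of the compounds shown alone.

Three compounds of the series have a number in an in vitro functional assay on HEK285-7 cells for antagonist activity at prostaglandin D2 receptor 2 (Homo sapiens), read by BRET and beta-arrestin recruitment; a lower number here means a smaller maximal response, a higher number a larger maximal response. Compound 1 `O=C(O)Cc1sc(C(c2ccc(F)cc2)c2ccc(F)cc2)nc1-c1ccc(Cl)cc1` gives 80%. Compound 2 `O=C(O)Cc1sc(C(c2ccc(F)cc2)c2ccc(F)cc2)nc1-c1cc(F)nc(F)c1` gives 80%. Compound 3 `O=C(O)Cc1sc(C(c2ccc(F)cc2)c2ccc(F)cc2)nc1-c1ccnc(O)c1` gives 60%, the lowest of the three; the step of a number 20 percentage points lower from compound 1 to compound 3 (beyond the scatter) and the step of a number 20 percentage points lower from compound 2 to compound 3 (beyond the scatter) both run downward, while no change at the digits printed from compound 1 to compound 2 (within the scatter) stays flat.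

Compound 4 `CN(C)c1cc(-c2nc(C(c3ccc(F)cc3)c3ccc(F)cc3)sc2CC(=O)O)ccn1` is not yet measured. Its difference from compound 3 is dimethylamino in place of hydroxy on an aromatic carbon.

Among the compounds with values here, no measured pair carries this exact exchange, so the bearing steps are indirect. Both downward steps into compound 3 coincide with the 2-hydroxypyridin-4-yl arm arriving; the steps of a number 20 percentage points lower from compound 1 to compound 3 (beyond the scatter) and a number 20 percentage points lower from compound 2 to compound 3 (beyond the scatter) are of modest size, and compound 1 and compound 2, which lack the hydroxy, sit together. Compound 4 also lacks the hydroxy, but carries a dimethylamino instead of a halogen or hydrogen, and nothing measured shows what that group does here.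

The expectation is therefore a partial return toward the level of compound 1 and compound 2, with wide uncertainty: the step of a number 10 percentage points higher from compound 3 to compound 4 (within the scatter) is expected to be upward. Compound 4 is estimated at 70%, within 55% to 85%.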

Compound 4, largest response reached (reported as efficacy), in percent of the reference or control that the assay uses: 80%
Beside the measured number, compound 4's estimate is 10 percentage points below it, and the stated range covers the measured number.
By their numbers in this assay, from the lowest: compound 3; then compounds 1, 2 and 4 (each within the scatter of the next).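

In this assay, within the data shown here, placing dimethylamino in place of hydroxy on the aromatic carbon next to the ring nitrogen gives the first direct reading of an exchange at this position (a number 20 percentage points higher from compound 3 to compound 4 (beyond the scatter)). The 2-(dimethylamino)pyridin-4-yl arm also reads level with the other two arms (no change at the digits printed from compound 2 to compound 4 (within the scatter); no change at the digits printed from compound 1 to compound 4 (within the scatter)), so a substituent of three heavy atoms at this carbon is compatible with the same maximal response as the 2,6-difluoropyridin-4-yl and 4-chlorophenyl arms, and among the four compounds only compound 3, with its hydroxy, stands apart. Why the hydroxy alone goes with the lower number finds no explanation in the data at hand.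

Still open, as far as these compounds go, is whether compound 4 owes its reading simply to the absence of the hydroxy or to something particular to dimethylamino, a question that a primary amine, a methoxy or a morpholine on this same carbon would help to separate. Also open, from the compounds shown here alone, is whether the lower reading of compound 3 is peculiar to hydroxy or would recur with other groups on this carbon, such as a carboxamide or a longer alkoxy chain.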